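The source may report more compounds than this note shows. Statements on the series, on what has been measured and on what is new or still open speak of the compounds shown alone.

Working notes on the series. Compound 1 `c1ccc(Cn2nnc3c(NC4CCCC4)nc(-c4ccccc4)nc32)cc1` gives 11000000 nM in an assay on isolated protein for binding affinity to adenosine receptor A1 (Bos taurus); on this read-out lower numbers stand for stronger inhibition and higher numbers for weaker inhibition; among the three measured compounds it stands at the highest number. Compound 2 `FC(F)(F)c1ccccc1Cn1nnc2c(NC3CCCC3)nc(-c3ccccc3)nc21` gives 600000 nM, and compound 3 `Clc1ccccc1Cn1nnc2c(NC3CCCC3)nc(-c3ccccc3)nc21` gives 9000000 nM. The step of an 18-fold lower number from compound 1 to compound 2 (1.26 log units; beyond the scatter) is large, while a 1.2-fold lower number from compound 1 to compound 3 (0.09 log units; within the scatter) stays within the scatter; both steps alter the aromatic carbon of the benzyl group, not the amine.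

Compound 4 `c1ccc(Cn2nnc3c(NC4CC4)nc(-c4ccccc4)nc32)cc1` differs from compound 1 by cyclopropyl in place of cyclopentyl on a nitrogen on an aromatic ring. Among the compounds with values here, no measured step touches the group on this nitrogen, so the measured steps give no direct guide. With the shared core otherwise unchanged, a step of uncertain direction, plausibly toward a higher number, is expected: a 1.8-fold higher number from compound 1 to compound 4 (0.26 log units; within the scatter). Compound 4 is therefore estimated at 20000000 nM, within 3000000 nM to 100000000 nM.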

Compound 4, inhibition constant: 11000000 nM
Compound 4: middle estimate off by 1.8-fold (0.26 log units), on the high side; the range from low to high includes it.
By their numbers in this assay, from the lowest: compound 2; then compounds 3, 1 and 4 (each within the scatter of the next).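

In this assay, within the data shown here, the change from cyclopentylamino to cyclopropylamino gives no change at the digits printed from compound 1 to compound 4 (within the scatter) and is the first reading at this nitrogen, since the earlier steps changed only the benzyl group. With the shared core held, the smaller ring leaves the number within the scatter. Nothing available explains this result.

Open, going by these compounds, is whether a cyclohexyl ring or an open-chain group such as butyl on this nitrogen would also stay within the scatter. Also open, on these data alone, is whether trifluoromethyl on the benzyl group gives a similar step when cyclopropyl is present.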